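Indole for Benzimidazole on an Arylpiperazine Pyridazinone Ligand

A few compounds are considered here, and "the series" means these few. Any claim that something is new, unique, unknown or untested is made for them only; others in the source may bear on it.

Of the compounds shown here, three built on a shared core have been measured in an assay on cell membranes from brain for binding affinity to Adrenergic receptor alpha-1 (Rattus norvegicus), read by radioligand binding; on this read-out lower numbers stand for stronger inhibition and higher numbers for weaker inhibition. Compound 1 `COc1ccccc1N1CCN(CCCCn2nc(-n3cnc4ccccc43)ccc2=O)CC1` gives 1.1 nM, the lowest of the three numbers. Compound 3 `O=c1ccc(-n2cnc3ccccc32)nn1CCCCN1CCN(c2ccccc2Cl)CC1` gives 1.3 nM, and the step of a 1.2-fold higher number from compound 1 to compound 3 (0.07 log units; within the scatter) shows that swapping the substituent on the arylpiperazine leaves the result essentially unchanged. Compound 2 `COc1ccccc1N1CCN(CCCCCCn2nc(-n3cnc4ccccc43)ccc2=O)CC1`, which carries a longer chain between the piperazine and the pyridazinone, gives 6.4 nM, so the chain length matters more than the aryl substituent in this set.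

Compound 4 `COc1ccccc1N1CCN(CCCCn2nc(-n3ccc4ccccc43)ccc2=O)CC1` differs from compound 1 at the heteroaryl end: 1H-indol-1-yl in place of 1H-benzimidazol-1-yl on an aromatic carbon. Among the compounds with values here, none of the measured steps touches this part of the molecule; the only one-place step, from compound 1 to compound 3, concerns the arylpiperazine and was within the scatter. Within the data shown here, with no direct precedent, the change is expected to move this assay only modestly, if at all, in the direction of a weaker number. The expected step is a 1.8-fold higher number from compound 1 to compound 4 (0.26 log units; within the scatter). Compound 4 is therefore estimated at 2 nM, with a range from 0.7 nM to 6 nM.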

Compound 4, inhibition constant: 0.9 nM
Compound 4: the middle estimate sits 2.2-fold (0.35 log units) above what was measured; measured number inside the range.
By their numbers in this assay, from the lowest: compounds 4, 1 and 3 (each within the scatter of the next); then compound 2.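

The exchange at this position, on the aromatic carbon next to the ring nitrogen, had no precedent among the earlier compounds, and it is the first change shown at the heteroaryl end. In this assay the step is a 1.2-fold lower number from compound 1 to compound 4 (0.09 log units; within the scatter), so 1H-indol-1-yl, with carbon in place of the second ring nitrogen of 1H-benzimidazol-1-yl and one hydrogen-bond acceptor fewer, reads the same as that group within the scatter. Nothing measured here explains this result.

The compounds shown leave open whether a smaller group at this carbon, such as an imidazol-1-yl ring, a phenyl ring or a simple amine, would keep the number. They also leave open whether 1H-indol-1-yl behaves the same alongside the chloro group of compound 3 or the longer chain of compound 2.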